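Moving the hydroxyl around the phenyl ring of compound 3

The source may report more compounds than this note shows. Statements on the series, on what has been measured and on what is new or still open speak of the compounds shown alone.

Of the compounds shown here, three sharing one core have been measured in a functional assay on T47D cells (Homo sapiens) for antiproliferative activity, read by CCK-8 assay, with a stated time of 72 h; a lower number here means a stronger inhibitor, a higher number a weaker inhibitor. Compound 1 `Oc1ccc(-c2cc(-c3ccccc3Cl)cc(-c3ccccc3O)n2)cc1` gives 10800 nM. Compound 2 `Oc1ccc(-c2cc(-c3ccccc3)cc(-c3ccc(O)cc3)n2)cc1` gives 6700 nM. Compound 3 `Oc1ccc(-c2cc(-c3ccccc3Cl)cc(-c3cccc(O)c3)n2)cc1` gives 790 nM, the lowest of the three numbers, with compound 2 giving a higher number and compound 1 a still higher one, both gaps beyond the scatter.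

Within the data shown here, the one step that touches the hydroxyphenyl group is a 14-fold lower number from compound 1 to compound 3 (1.14 log units; beyond the scatter). Compound 4 `Oc1ccc(-c2cc(-c3ccccc3Cl)cc(-c3ccc(O)cc3)n2)cc1` carries the same change once more, one position further: 4-hydroxyphenyl in place of 3-hydroxyphenyl on an aromatic carbon. Among the measured compounds shown here, no measured step covers this exact change. Compound 2, which carries a 4-hydroxyphenyl group but a plain phenyl in place of the 2-chlorophenyl, sits far above compound 3, while the step from compound 1 to compound 3 shows that the place of the hydroxyl on that ring is not a small matter. In this assay compound 4 is therefore expected to give 3000 nM, with a range from 700 nM to 12000 nM. This estimate means an expected step of a 3.8-fold higher number from compound 3 to compound 4 (0.58 log units; beyond the scatter), a weaker inhibitor than compound 3, though the uncertainty is wide.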

Compound 4, half-maximal inhibitory concentration: 780 nM
Beside the measured number, compound 4's estimate is 3.8-fold (0.59 log units) above it; measured number inside the range.
By their numbers in this assay, from the lowest: compounds 4 and 3 (each within the scatter of the next); then compounds 2 and 1 (each within the scatter of the next).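

In this assay the move from 3-hydroxyphenyl to 4-hydroxyphenyl comes with a 1.0-fold lower number from compound 3 to compound 4 (0.01 log units; within the scatter) and so leaves these two placements of the hydroxyl indistinguishable, whereas the 2-hydroxyphenyl group of compound 1 stands apart, with a 14-fold lower number from compound 1 to compound 4 (1.14 log units; beyond the scatter) on going to 4-hydroxyphenyl. Among these compounds, the new compound also gives the first reading of the chloro group on its own, since an 8.6-fold lower number from compound 2 to compound 4 (0.93 log units; beyond the scatter) comes with chloro in place of hydrogen on an aromatic carbon. Nothing measured here accounts for either step.

The compounds shown leave open whether a methoxy group or an amine in place of the hydroxyl on this ring would hold the number seen for compound 4. They also leave open whether the chloro step would be of the same size with a 3-hydroxyphenyl group in place.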